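Swapping the Aromatic Group on a Shared Core

The compounds below may be only part of what the source reports. "The series", "measured", "known", "first", "only" and "open" are said of these compounds alone.

Compound 1 `CCC1=C(O)c2c(oc(-c3ccccc3)cc2=O)C(CC)(CC)C1=O`: > 236 uM, a limit
Compound 2 `CCC1=C(O)c2c(oc(-c3ccc(SC)cc3)cc2=O)C(CC)(CC)C1=O`: > 52.1 uM, a limit
Compound 3 `CCC1=C(O)c2c(oc(-c3ccc(OC)c(F)c3)cc2=O)C(CC)(CC)C1=O`: 26.7 uM

These three compounds share one core and differ only in the aromatic group attached to it. Among the measured compounds shown here, in a functional assay on KB cells (Homo sapiens) for antiproliferative activity, read by sulforhodamine B assay, with a stated time of 3 days (on this read-out higher numbers stand for an effect only at larger amounts of compound and lower numbers for an effect already at smaller amounts), compound 3 gives 26.7 uM, the only true number of the three. The values for compound 1 and compound 2 are both limits.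

The next compound, compound 4 `CCC1=C(O)c2c(oc(-c3ccc(O)c(C)c3C)cc2=O)C(CC)(CC)C1=O`, carries 4-hydroxy-2,3-dimethylphenyl in place of 3-fluoro-4-methoxyphenyl on an aromatic carbon. For the measured compounds named here, no measured step makes this exact exchange. The nearest evidence is an at least 8.8-fold lower number from compound 1 to compound 3 (0.94 log units; beyond the scatter), which shows that the aromatic group can move the number beyond the scatter. The other step into compound 3 is an at least 1.9-fold lower number from compound 2 to compound 3 (0.29 log units; that floor lies within the scatter), while a step that the two limits leave unreadable from compound 1 to compound 2 adds little. Both steps into compound 3 rest on limits, so they give floors rather than sizes.

With so little to go on, no step beyond the scatter is expected in this assay, although a drift toward a higher number seems somewhat more likely than the reverse. The expected change is a 1.3-fold higher number from compound 3 to compound 4 (0.12 log units; within the scatter). Compound 4 is estimated at 35 uM, with an expected range from 11 uM to 100 uM.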

Compound 4, concentration for half-maximal effect: 6.5 uM
Compound 4: the middle estimate sits 5.4-fold (0.73 log units) above what was measured; measured number below the stated range.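

In this assay, among the compounds shown here, the exchange on this aromatic carbon, next to the ring oxygen, gives a 4.1-fold lower number from compound 3 to compound 4 (0.61 log units; beyond the scatter), and this is the first step that joins two true numbers and so has a readable size beyond the scatter. The group leaving and the group entering each hold 9 heavy atoms and one six-membered aromatic ring of carbon only, yet 4-hydroxy-2,3-dimethylphenyl brings 1 hydrogen-bond donor where 3-fluoro-4-methoxyphenyl has 0, so the number moves even with the size of the group unchanged in that count. The other two steps, an at least 8.0-fold lower number from compound 2 to compound 4 (0.90 log units; beyond the scatter) and an at least 36-fold lower number from compound 1 to compound 4 (1.55 log units; beyond the scatter), each start from a limit of the assay and therefore give floors, the second of them large.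

What lies behind the step stays open, as nothing at hand bears on a cause. Also open, as far as these compounds go, is whether the hydroxy group or the two methyl groups carry the change, and how an amine or a carboxylic acid in place of that hydroxy group would read in this assay.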